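The source may hold more compounds than are shown below. What is called first, only, known or untested is meant among the compounds shown, and "the series" means these compounds.

Measured in a functional assay on SMMC-7721 cells (Homo sapiens) for cytotoxicity, read by MTT assay, with a stated time of 24 h; on this read-out lower numbers stand for stronger inhibition and higher numbers for weaker inhibition:
- compound 1 `N#Cc1ccc(/C=C2\CN(S(=O)(=O)c3ccc(F)cc3)C/C(=C\c3ccc(C#N)cc3)C2=O)cc1`: 20100 nM
- compound 2 `COc1cc(/C=C2\CN(S(=O)(=O)c3ccc(F)cc3)C/C(=C\c3cc(OC)c(OC)c(OC)c3)C2=O)cc(OC)c1OC`: 3840 nM
- compound 3 `CC(=O)Nc1ccc(S(=O)(=O)N2C/C(=C\c3cccc([N+](=O)[O-])c3)C(=O)/C(=C/c3cccc([N+](=O)[O-])c3)C2)cc1`: 8420 nM

Compound 2 has the lowest number of the three in this assay. Compound 3 lies nearest to it and compound 1 furthest, and both gaps are beyond the usual scatter.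

Compound 4 `COc1cc(/C=C2\CN(S(=O)(=O)c3ccc(NC(C)=O)cc3)C/C(=C\c3cc(OC)c(OC)c(OC)c3)C2=O)cc(OC)c1OC` differs from compound 2 in one place, with acetamido in place of fluoro on an aromatic carbon. Going by the values given here, no two measured compounds differ in one place only, so the size of this step has no direct precedent. Among the compounds with values here, compound 3 is the only measured compound carrying the acetamido group. Compound 3 gives 8420 nM, but it also differs from compound 2 in its other groups, so it offers only weak guidance. A step beyond the scatter is not expected, though the estimate leans towards a higher number. The expected change is a 1.4-fold higher number from compound 2 to compound 4 (0.16 log units; within the scatter). For compound 4 the estimated value is 5500 nM, with an expected range of 2200 nM to 14000 nM.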

Compound 4, half-maximal inhibitory concentration: 3470 nM
For compound 4 the middle estimate is 1.6-fold (0.20 log units) above the measured one; the range from low to high includes it.
By their numbers in this assay, from the lowest: compounds 4 and 2 (each within the scatter of the next); then compound 3; then compound 1.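

In this assay the series gains its first single-place comparison: the change from 4-fluorophenyl to 4-acetamidophenyl gives a 1.1-fold lower number from compound 2 to compound 4 (0.04 log units; within the scatter) and so leaves the two compounds unseparated. At this position, on an aromatic carbon para to a large group, acetamido with its 4 heavy atoms, hydrogen-bond donor and hydrogen-bond acceptor can therefore replace fluoro without a step beyond the scatter, at least with the rest of compound 2 held fixed. No independent measurement bears on this result.

On these data alone, whether fluoro and acetamido stay interchangeable alongside the nitrile-bearing groups of compound 1 or the nitro-bearing groups of compound 3 remains open. Also open, as far as these compounds go, is whether an amino group or a carboxylic acid at the same position would leave the number within the scatter.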